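Thiazole for methoxyethyl on a tolerated series

The source may report more compounds than this note shows. Statements on the series, on what has been measured and on what is new or still open speak of the compounds shown alone.

Measured in an ADME assay on HEK293 cells (Homo sapiens) for cytotoxicity, read by ATP content, with a stated time of 6 h; a lower number here means that less compound is tolerated, a higher number that more compound is tolerated:
- Compound 1 `CCCCNc1nc(N)nc2ccn(Cc3ccccc3)c12`: > 24000 nM (a limit)
- Compound 2 `CCCCNc1nc(N)nc2ccn(Cc3cccnc3)c12`: > 24000 nM (a limit)
- Compound 3 `COCCCNc1nc(N)nc2ccn(Cc3ccccn3)c12`: > 24000 nM (a limit)

Compound 3 reports only a limit, > 24000 nM, and no number. The other two compounds stand in the same way: the limit of > 24000 nM in this assay, at which 3 of the 3 values shown sit.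

The next structure is compound 4 `Cc1nc(CNc2nc(N)nc3ccn(Cc4ccccn4)c23)cs1`, which carries 2-methyl-1,3-thiazol-4-yl in place of 2-methoxyethyl on a saturated chain carbon bound to a nitrogen on an aromatic ring. Among the compounds with values here, no measured step sits at this place. Within the data shown here, the only measured step, a step that the two limits leave unreadable from compound 1 to compound 2, is pyridin-3-yl in place of phenyl on a saturated chain carbon bound to an aromatic nitrogen. It lies at a different place and gives no size to carry over.

The expectation therefore rests on the three limits alone, and no direction can be argued from them. In this assay the expected outcome is a number no higher from compound 3 to compound 4 (the limit leaves the size open), with nothing beyond the scatter foreseen. For compound 4 the estimated value is 24000 nM, expected to fall between 10000 nM and 40000 nM, with another limit the likeliest report.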

Compound 4, half-maximal cytotoxic concentration: > 24000 nM
Compound 4: no number, only a limit; the forecaster's own chance of this, stated with the estimate: 80%; the middle value sits exactly at the limit.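

In this assay, within the data shown here, compound 4 gives > 24000 nM, a limit and not a number, so no step from compound 3 to compound 4 can be read. The series stays at that ceiling: the limit of > 24000 nM in this assay, at which 4 of the 4 values shown sit.

The compounds shown leave open at what concentration any of them reduces the ATP read-out by half, and whether 2-methyl-1,3-thiazol-4-yl in place of 2-methoxyethyl changes that concentration.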